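Replacing a triazole arm with an aminothiazole

The compounds below may be only part of what the source reports. "The series", "measured", "known", "first", "only" and "open" are said of these compounds alone.

compound 1 `CC(C)C(Cc1nnc[nH]1)c1ccc(-c2ccc3cccc(F)c3c2)[nH]c1=O`: 10 nM
compound 2 `CCn1ncc2c(F)cc(-c3ccc(C(CC)(CC)c4nnc(C)[nH]4)c(=O)[nH]3)cc21`: 34 nM
compound 3 `CCC(CC)(c1nnc[nH]1)c1ccc(-c2ccc3cccc(F)c3c2)[nH]c1=O`: 19 nM

Of the compounds shown here, three sharing the same core have been measured in an assay on CHO cells for displacement of a labelled ligand from prostaglandin E2 receptor EP3 subtype (Homo sapiens), read by radioligand binding; a lower number here means a stronger inhibitor, a higher number a weaker inhibitor. Compound 1 gives 10 nM, the lowest of the three numbers. Compound 3 gives 19 nM; its gap from compound 1 falls within the usual scatter, so the two cannot be told apart. Compound 2 gives 34 nM, a gap from compound 1 that lies beyond the scatter.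

Compound 4 `CC(C)C(c1cnc(N)s1)c1ccc(-c2ccc3cccc(F)c3c2)[nH]c1=O` has not yet been measured. It differs from compound 1 by 2-amino-1,3-thiazol-5-yl in place of (4H-1,2,4-triazol-3-yl)methyl on a saturated chain carbon bound to an aromatic carbon and a saturated chain carbon. For the measured compounds named here, no measured pair shows this change, so its effect can only be guessed. Compound 1 and compound 3 both carry the (4H-1,2,4-triazol-3-yl)methyl group and both sit at the low end of this assay, while compound 4 gives that group up entirely. A modest step toward a higher number is expected, a 3.0-fold higher number from compound 1 to compound 4 (0.48 log units; beyond the scatter), though the outcome may also stay within the scatter. For compound 4 the estimate is 30 nM, with a range from 8 nM to 120 nM.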

Compound 4, inhibition constant: 16 nM
For compound 4 the middle estimate is 1.9-fold (0.27 log units) above the measured one; the range from low to high includes it.
By their numbers in this assay, from the lowest: compounds 1, 4, 3 and 2 (each within the scatter of the next, the first and the last beyond it).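

On a saturated chain carbon bound to an aromatic carbon and a saturated chain carbon, the (4H-1,2,4-triazol-3-yl)methyl group can give way to 2-amino-1,3-thiazol-5-yl, and a 1.6-fold higher number from compound 1 to compound 4 (0.20 log units; within the scatter) is the size of that change in this assay. For the compounds shown here, this is the first measured pair at this position, and it shows that a number in this range does not depend on keeping the triazole arm: a different five-membered aromatic ring, one containing sulfur, serves within the scatter. Nothing measured here explains why the two groups read so alike.

As far as these compounds go, it remains open whether the amino group on the thiazole matters, or how a methylamino group or a plain hydrogen in its place would read. The same replacement on the chain of compound 3 is also untested among the compounds shown.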